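Swapping 4-Chlorophenyl for 2-Fluorophenyl on a Shared Core

This account rests on a few compounds, and the source may have more. Where it says the series, first, only, none or still open, it means among the compounds named here.

Compound 1 `c1ccc(-c2cn3ccnc3c(-c3ccc4ncn(C5CCCCC5)c4c3)n2)cc1`: 22.9%
Compound 2 `Clc1ccc(-c2cn3ccnc3c(-c3ccc4ncn(C5CCCCC5)c4c3)n2)cc1`: 15.8%

Within the data shown here, in a functional assay on SNB-19 cells (Homo sapiens) for inhibition, read by sulforhodamine B assay, with a stated time of 48 h, tested at 10 uM (on this read-out higher numbers stand for more inhibition at the one concentration tested (going by the name of the read-out) and lower numbers for less inhibition), compound 2 gives 15.8%, and the gap to its only neighbour, compound 1, is within the scatter, as a number 7.1 percentage points lower from compound 1 to compound 2 (within the scatter) shows. Compound 3 `Fc1ccccc1-c1cn2ccnc2c(-c2ccc3ncn(C4CCCCC4)c3c2)n1` differs from compound 2 by 2-fluorophenyl in place of 4-chlorophenyl on an aromatic carbon. Among the measured compounds shown here, the one measured step, chloro in place of hydrogen on an aromatic carbon, touched the same ring and stayed within the scatter, so no step beyond the scatter is expected here either. Compound 3 is estimated at 18%, with a range from 5% to 32%. This estimate means an expected a number 2.2 percentage points higher from compound 2 to compound 3 (within the scatter).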

Compound 3, a percentage reported as inhibition, at one concentration (the size of the read-out at that concentration, not a potency): 7.56%
For compound 3 the middle estimate is 10.4 percentage points above the measured one; measured number inside the range.
By their numbers in this assay, from the lowest: compounds 3, 2 and 1 (each within the scatter of the next, the first and the last beyond it).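

In this assay, among these compounds, 2-fluorophenyl gives the first step on this ring that lies beyond the scatter, a modest one (a number 15.3 percentage points lower from compound 1 to compound 3 (beyond the scatter)). Replacing 4-chlorophenyl with 2-fluorophenyl stays within the scatter (a number 8.2 percentage points lower from compound 2 to compound 3 (within the scatter)), so these two groups cannot be told apart here, although they differ in both halogen and ring position. Nothing available explains the lower number for 2-fluorophenyl.

From the compounds shown here alone, whether 4-fluorophenyl would match 2-fluorophenyl remains open. So does whether an amine or a methoxy group on this ring would raise the number above that of compound 1.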